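The compounds below may be only part of what the source reports. "The series", "measured", "known", "first", "only" and "open" are said of these compounds alone.

Measured compounds in an ADME assay on CCD-1095SK cells (Homo sapiens) for antiproliferative activity, read by crystal violet staining, with a stated time of 96 h; on this read-out lower numbers stand for an effect already at smaller amounts and higher numbers for an effect only at larger amounts of compound:

Compound 1, `O[C@H]1[C@H](Oc2ccc3ccccc3c2)OC[C@@H](O)[C@@H]1F`, gives 72 uM.
Compound 2, `CO[C@@H]1[C@@H](O)[C@H](Oc2ccc3ccccc3c2)OC[C@H]1O`, gives 17 uM.
Compound 3, `CO[C@@H]1CO[C@@H](Oc2ccc3ccccc3c2)[C@H](O)[C@H]1O`, gives 93 uM.

On these numbers compound 2 stands lowest of the three in this assay. For the measured compounds named here, its nearest neighbour is compound 1, and the one step that connects two of the measured compounds runs between them: a 4.2-fold lower number from compound 1 to compound 2 (0.63 log units; beyond the scatter). Going by the values given here, compound 3 sits further away still, with a number above that of compound 2, though no single-point step links those two structures.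

Compound 4, `O[C@@H]1CO[C@@H](Oc2ccc3ccccc3c2)[C@H](O)C1`, is not yet measured. It differs from compound 2 in one place: hydrogen in place of methoxy on a saturated ring carbon. Among the compounds with values here, the only step that bears on this change is the one from compound 1 to compound 2, where a methoxy arriving on a saturated ring carbon lowered the number modestly. Taking the methoxy away again, now in favour of hydrogen rather than fluoro, is therefore expected to move the number back upward in this assay, by a modest step: a 2.4-fold higher number from compound 2 to compound 4 (0.37 log units; beyond the scatter). Compound 4 is accordingly estimated at 40 uM, within a range from 15 uM to 110 uM.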

Compound 4, concentration for half-maximal effect: 79 uM
Compound 4: middle estimate off by 2.0-fold (0.30 log units), on the low side, within the range that was stated.
By their numbers in this assay, from the lowest: compound 2; then compounds 1, 4 and 3 (each within the scatter of the next).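

In this assay, the new result shows that the low number of compound 2 does not survive the loss of methoxy from this saturated ring carbon, with a 4.6-fold higher number from compound 2 to compound 4 (0.67 log units; beyond the scatter) once hydrogen takes its place. The earlier compounds had shown methoxy only against fluoro, and hydrogen now supplies the missing comparison: with a 1.1-fold higher number from compound 1 to compound 4 (0.04 log units; within the scatter), fluoro and hydrogen at this place cannot be told apart in this read-out. Of the three groups compared at this ring carbon, methoxy alone is therefore linked to the lower number, while fluoro and hydrogen give values within the scatter of each other, but no measurement here accounts for that difference.

From the compounds shown here alone, what remains open is whether the effect needs the whole methoxy group or would persist with a different group at the same ring carbon, such as an ethoxy, a longer ether chain or an amine. Going by these compounds, it is also open whether any of these would bring the number below that of compound 2 or return it to the level shared by compound 1 and compound 4.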